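Side-chain variation on the shared core, compound 2 to compound 3

A few compounds are considered here, and "the series" means these few. Any claim that something is new, unique, unknown or untested is made for them only; others in the source may bear on it.

Compound 1 `CCCCCCCCCCC/C(O)=C1/C(=O)[C@H](Cc2ccccc2)N(C(=O)OC(C)(C)C)C1=O` carries the shortest chain of the three compounds noted here. Among the compounds with values here, in an assay on isolated protein for inhibition of Trypsin (Homo sapiens) (on this read-out higher numbers stand for weaker inhibition and lower numbers for stronger inhibition), compound 1 gives 2100 nM, the only number in the set. On these data alone, compound 2 `CCCCCCCCCCCCCCC/C(O)=C1/C(=O)[C@H](Cc2ccccc2)N(C(=O)OC(C)(C)C)C1=O` keeps the core and differs only in the length of its saturated chain; in this assay compound 2 stands at "not determined" (no result reported), so no number can be placed against it and its position relative to compound 1 is unknown. Compound 3 `CCCCCCCC/C=C\CCCCCCC/C(O)=C1/C(=O)[C@H](Cc2ccccc2)N(C(=O)OC(C)(C)C)C1=O` is the next variation. The change from compound 2 to compound 3 is dec-1-en-1-yl in place of octyl on a saturated chain carbon, seven bonds along the chain from a double-bonded chain carbon. Within the data shown here, no measured pair shows what a longer chain or an added double bond does, so the size of the step from compound 2 to compound 3 in this assay cannot be read from the data; the expectation is a step of no settled direction, most likely within or only a little beyond the scatter. Among the measured compounds shown here, the single anchor is compound 1 at 2100 nM in this assay. For compound 3 the estimate in this assay is 2500 nM, expected to fall between 600 nM and 10000 nM.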

Compound 3, half-maximal inhibitory concentration: 2300 nM
Estimate against measurement, compound 3: 1.1-fold (0.04 log units) above, and the stated range covers the measured number.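

In this assay, within the data shown here, the longer, unsaturated side chain gives a 1.1-fold higher number from compound 1 to compound 3 (0.04 log units; within the scatter), the first readable step. This position therefore tolerates the larger, unsaturated group with no difference beyond the scatter on this read-out, although compound 2 has no number and any step involving it cannot be read. No supporting evidence bears on why the read-out holds across this change.

The step changes chain length and adds a double bond together, so these compounds cannot show what either change does alone, or whether the geometry of the double bond matters. Also open, on these data alone, is whether the same position would hold the read-out with a chain ending in a carboxylic acid or an amine, or with a chain shorter than butyl, any of which would test the flat result from compound 1 to compound 3 more sharply than another long hydrocarbon chain.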